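The compounds below may be only part of what the source reports. "The series", "measured", "known", "first", "only" and "open" are said of these compounds alone.

In a functional assay on MCF7 cells (Homo sapiens) for inhibition (on this read-out lower numbers stand for stronger inhibition and higher numbers for weaker inhibition), compound 1 `CC/C(=C(/c1ccc(/C=C/C(=O)O)cc1)c1cc2ccccc2[nH]1)c1cccc(C)c1` gives 140 nM and compound 2 `CC/C(=C(/c1ccc(/C=C/C(=O)O)cc1)c1cc2ccccc2[nH]1)c1ccc(C#N)cc1Cl` gives 49 nM. Among the two numbers measured so far, compound 2 stands lowest, and the one step that has been measured, a 2.9-fold lower number from compound 1 to compound 2 (0.46 log units; beyond the scatter), is the only guide available.

Compound 3 `CC/C(=C(/c1ccc(/C=C/C(=O)O)cc1)c1cc2ccccc2[nH]1)c1c(C)cccc1Cl` differs from compound 2 in one place: 2-chloro-6-methylphenyl in place of 2-chloro-4-cyanophenyl on a double-bonded chain carbon bound to a double-bonded chain carbon and a saturated chain carbon. This change removes the nitrile that sets compound 2 apart from compound 1, while keeping the chlorine and bringing back a methyl group, so compound 3 resembles compound 1 as much as compound 2. Going by the values given here, no measured step separates the effect of the nitrile from that of the chlorine and methyl, so the direction rests on a single comparison.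

Compound 3 is therefore expected to give a number nearer to that of compound 1, a step of a 2.2-fold higher number from compound 2 to compound 3 (0.35 log units; beyond the scatter) toward weaker inhibition, with an estimate of 110 nM in this assay and a range from 40 nM to 300 nM.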

Compound 3, half-maximal inhibitory concentration: 30 nM
Estimate against measurement, compound 3: 3.7-fold (0.56 log units) above, and the stated range ends above it.
By their numbers in this assay, from the lowest: compounds 3 and 2 (each within the scatter of the next); then compound 1.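

In this assay, the result shows that this position does not depend on the nitrile: the step of a 1.6-fold lower number from compound 2 to compound 3 (0.21 log units; within the scatter) lies within the scatter, so 2-chloro-6-methylphenyl and 2-chloro-4-cyanophenyl cannot be told apart here. The step of a 4.7-fold lower number from compound 1 to compound 3 (0.67 log units; beyond the scatter) lies beyond the scatter, so a second replacement for 3-methylphenyl now lowers the number, and both replacements carry a chlorine, although each also differs from 3-methylphenyl in other ways. Nothing measured here explains why these changes have these effects.

The compounds shown leave open whether the chlorine alone accounts for the lower numbers, since none has a chlorine as the only group on this ring. A 2-chlorophenyl or an unsubstituted phenyl at this place would test that directly.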